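The source may report more compounds than this note shows. Statements on the series, on what has been measured and on what is new or still open speak of the compounds shown alone.

Compound 1, with the structure `Cc1ncc([N+](=O)[O-])n1CCOc1ccc(Cl)c(Cl)c1`, was examined in a functional assay on MCF7 cells (Homo sapiens) for cytotoxicity, read by MTT assay, with a stated time of 24 h (on this read-out lower numbers stand for stronger inhibition and higher numbers for weaker inhibition), where compound 1 gives 69.7 ug/mL. Compound 2, with the structure `Cc1cc(OCCn2c([N+](=O)[O-])cnc2C)ccc1F`, was tested in the same way, and in this assay compound 2 gives 116 ug/mL. Of the two numbers recorded so far, compound 2 carries the larger one, but the gap between compound 2 and compound 1 falls within the usual scatter of repeated measurements, so the two compounds cannot be told apart on these data.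

Compound 3, with the structure `Cc1ncc([N+](=O)[O-])n1CCOc1ccc(F)c(Cl)c1`, is the next candidate. Its structure differs from that of compound 2 in one place: chloro in place of methyl on an aromatic carbon. Within the data shown here, no pair of measured compounds shows the effect of this change, so nothing measured speaks for a step in either direction beyond the scatter. With only the two numbers above as anchors, compound 3 is expected to give a value close to that of compound 2, with a step of about a 1.3-fold lower number from compound 2 to compound 3 (0.11 log units; within the scatter) in this assay. The estimate for compound 3 in this assay is therefore 90 ug/mL, within a range from 45 ug/mL to 180 ug/mL.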

Compound 3, half-maximal inhibitory concentration: 110 ug/mL
Compound 3: the middle estimate sits 1.2-fold (0.09 log units) below what was measured; the measured number falls inside the stated range.
By their numbers in this assay, from the lowest: compounds 1, 3 and 2 (each within the scatter of the next).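

In this assay, the step for chloro in place of methyl on an aromatic carbon, ortho to a fluoro group and meta to a large group, is now read directly as a 1.1-fold lower number from compound 2 to compound 3 (0.02 log units; within the scatter), so on these data the two groups cannot be told apart at this position. The second change now available, fluoro in place of chloro on an aromatic carbon, gives a 1.6-fold higher number from compound 1 to compound 3 (0.20 log units; within the scatter), so this swap also leaves the compounds indistinguishable, and neither step shows this part of the structure governing the read-out among the three compounds. No independent data are available to explain either result.

What the compounds shown leave open is whether a different kind of group at this position, such as an amine, a methoxy group or a carboxylic acid, would move the number beyond the scatter, since only methyl, chloro and fluoro appear on the aromatic ring here. Also open, as far as these compounds go, is whether a longer chain joining the aromatic ring to the shared core, or a change to the core itself, would separate compounds in this assay.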